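The compounds below may be only part of what the source reports. "The series", "measured", "known", "first", "only" and "open" are said of these compounds alone.

Compound 1 `CC1CCN(C2CCN(S(=O)(=O)c3cccc(N)c3)CC2)CC1` in a functional assay on DLD-1 cells (Homo sapiens) for antiproliferative activity, read by CellTiter-Glo, with a stated time of 72 h (a lower number here means a stronger inhibitor, a higher number a weaker inhibitor), gives 3400 nM.
Compound 2 `Cc1cccc(S(=O)(=O)N2CCC(N3CCC(C)CC3)CC2)c1` in this assay gives 25 nM.
Compound 3 `Cc1nc(Cl)sc1S(=O)(=O)N1CCC(N2CCC(C)CC2)CC1` in this assay gives 1.6 nM.

Compound 3 holds the lowest of the three numbers. Its nearest neighbour is compound 2, separated by the step of a 16-fold lower number from compound 2 to compound 3 (1.19 log units; beyond the scatter); its furthest is compound 1, separated by a 2100-fold lower number from compound 1 to compound 3 (3.33 log units; beyond the scatter). Compound 4 `CC1CCN(C2CCN(S(=O)(=O)c3ccc(F)cc3F)CC2)CC1` differs from compound 3 in one place: 2,4-difluorophenyl in place of 2-chloro-4-methyl-1,3-thiazol-5-yl on a sulfonyl sulfur. The step that bears most directly on this change is a 16-fold lower number from compound 2 to compound 3 (1.19 log units; beyond the scatter), since it also exchanges the same 2-chloro-4-methyl-1,3-thiazol-5-yl group for a six-membered carbon ring on the sulfonyl sulfur. The step of a 140-fold lower number from compound 1 to compound 2 (2.13 log units; beyond the scatter) shows in addition that what sits on that phenyl ring can move the number a long way. Within the data shown here, no measured compound carries 2,4-difluorophenyl, so the size of the step is uncertain, but a higher number than compound 3 is expected, in the region of compound 2. For compound 4 in this assay the estimate is 30 nM, between 6 nM and 150 nM, which means an expected step of a 19-fold higher number from compound 3 to compound 4 (1.27 log units; beyond the scatter).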

Compound 4, half-maximal inhibitory concentration: 102 nM
The estimate for compound 4 lay 3.4-fold (0.53 log units) below the measured number, and the stated range covers the measured number.
By their numbers in this assay, from the lowest: compound 3; then compound 2; then compound 4; then compound 1.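

In this assay, a second six-membered carbon ring on the sulfonyl sulfur, 2,4-difluorophenyl, also falls well short of the 2-chloro-4-methyl-1,3-thiazol-5-yl group (a 64-fold higher number from compound 3 to compound 4 (1.80 log units; beyond the scatter)), so compound 3 now stands apart from two phenyl-bearing compounds rather than one. The two fluorines do not match the single methyl of the 3-methylphenyl group (a 4.1-fold higher number from compound 2 to compound 4 (0.61 log units; beyond the scatter)), although they still give a much lower number than the 3-aminophenyl group (a 33-fold lower number from compound 1 to compound 4 (1.52 log units; beyond the scatter)), which places compound 4 within the wide spread among the phenyl compounds. Nothing measured here explains these differences.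

The compounds shown leave open whether the chlorine or the methyl of the 2-chloro-4-methyl-1,3-thiazol-5-yl group matters more for the low number of compound 3. They also leave open where an unsubstituted phenyl, a pyridine ring or a thiophene ring on the sulfonyl sulfur would fall.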